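The compounds below may be only part of what the source reports. "The series", "measured", "known", "first", "only" and "open" are said of these compounds alone.

In an in vivo ADME assay on the whole organism (strain BALB/c) for pharmacokinetics, with Mus musculus as the target, read by LC-MS, at a dose of 5 mg/kg by the oral route (on this read-out higher numbers stand for fast clearance and lower numbers for slow clearance), compound 1 (`O=C(O)COc1ccc(Cl)cc1C#Cc1ccc(CO)cc1F`) gives 35 mL/min/kg and compound 2 (`Cc1ccc(S(=O)(=O)N2CCOCC2)cc1C#Cc1cc(Cl)ccc1OCC(=O)O`) gives 31.7 mL/min/kg, so these two values lie within the usual scatter of each other. Compound 3 (`Cc1ccc(S(C)(=O)=O)cc1C#Cc1cc(Cl)ccc1OCC(=O)O`) has not yet been measured. It differs from compound 2 in one place: methyl in place of morpholin-4-yl on a sulfonyl sulfur. Among the measured compounds shown here, no measured pair shows what this change does, so no direction can be favoured. The estimated step, a 1.1-fold lower number from compound 2 to compound 3 (0.02 log units; within the scatter), is expected to stay within the scatter. Compound 3 is estimated at 30 mL/min/kg, with an expected range of 14 mL/min/kg to 62 mL/min/kg.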

Compound 3, clearance: 23.3 mL/min/kg
For compound 3 the middle estimate is 1.3-fold (0.11 log units) above the measured one, and the stated range covers the measured number.
By their numbers in this assay, from the lowest: compounds 3, 2 and 1 (each within the scatter of the next).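

In this assay, among the compounds shown here, putting methyl in place of morpholin-4-yl on the sulfonyl sulfur gives a 1.4-fold lower number from compound 2 to compound 3 (0.13 log units; within the scatter) and so provides the first direct reading of this change. At this place, clearance in mice does not separate the six-membered ring from the single carbon, so removing the ring has no effect that can be told from the scatter. Nothing measured here offers an explanation for this result. Still open, from the compounds shown here alone, is whether an amine such as dimethylamino, or a longer chain such as ethyl, on the same sulfur would move clearance beyond the scatter.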